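Compound 3 to compound 4: replacing 2-carboxyethyl

The compounds below may be only part of what the source reports. "The series", "measured", "known", "first", "only" and "open" are said of these compounds alone.

In an ADME assay on L02 cells (Homo sapiens) for cytotoxicity, read by MTT assay, with a stated time of 72 h (a lower number here means a stronger inhibitor, a higher number a weaker inhibitor), compound 1 `COc1ccc(/C=C2\CNC/C(=C\c3ccc(OC)c(OC)c3)C2=O)cc1OC` gives 15100 nM. In this assay, compound 2 `COc1cc(/C=C2\CN(C)C/C(=C\c3cc(OC)c(OC)c(OC)c3)C2=O)cc(OC)c1OC` gives 26400 nM. Compound 3 `COc1cc(/C=C2\CN(C(=O)CCC(=O)O)C/C(=C\c3cc(OC)c(OC)c(OC)c3)C2=O)cc(OC)c1OC` is known only as a limit, > 60000 nM.

The next change leads to compound 4 `COc1cc(/C=C2\CN(C(=O)c3ccccc3F)C/C(=C\c3cc(OC)c(OC)c(OC)c3)C2=O)cc(OC)c1OC`, with 2-fluorophenyl in place of 2-carboxyethyl on a carbonyl carbon. Cut one bond further out, this reads (2-carboxyethyl)carbonyl to (2-fluorophenyl)carbonyl.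

Going by the values given here, one measured step bears on this change: an at least 2.2-fold higher number from compound 2 to compound 3 (0.35 log units; beyond the scatter). It brought in the (2-carboxyethyl)carbonyl group in place of methyl on an amine nitrogen in a ring. Compound 4 loses that group again, so the expectation is a return towards the values of the compounds without it, with compound 2 at 26400 nM as the closest reference. Among the compounds with values here, no measured compound carries 2-fluorophenyl, and the one step available starts from methyl, so the range is kept wide and its upper end stays close to the limit.

The expected change in this assay is a move to a lower number, estimated as an at least 3.0-fold lower number from compound 3 to compound 4 (0.47 log units; beyond the scatter). The estimate for compound 4 is 20000 nM, with an expected range of 7000 nM to 55000 nM.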

Compound 4, half-maximal inhibitory concentration: 4400 nM
Compound 4: middle estimate off by 4.5-fold (0.66 log units), on the high side; the measured number lies below the stated range.
By their numbers in this assay, from the lowest: compound 4; then compounds 1 and 2 (each within the scatter of the next). At a limit, above all of these: compound 3.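

Going by these compounds alone, the only earlier step on the amine nitrogen in the ring was an at least 2.2-fold higher number from compound 2 to compound 3 (0.35 log units; beyond the scatter), which left open whether any carbonyl group on that nitrogen would go with a higher number in this assay. Compound 4 also has a carbonyl carbon on that nitrogen, yet the direction reverses: a 6.0-fold lower number from compound 2 to compound 4 (0.78 log units; beyond the scatter). With that carbonyl held in place, changing only the group on it gives an at least 13-fold lower number from compound 3 to compound 4 (1.13 log units; beyond the scatter), so the high number of compound 3 goes with 2-carboxyethyl and not with the carbonyl on the nitrogen as such; that step is a bound and not a measured size, as compound 3 is known only as a limit: the limit of > 60000 nM in this assay, at which 1 of the 4 values shown sits.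

As far as these compounds go, whether the lower number of compound 4 goes with the fluorine or with the aromatic ring remains open, and a plain phenyl or a cyclohexyl on the same carbonyl would separate the two. From the compounds shown here alone, it is also open whether the high number of compound 3 follows the free carboxylic acid or the chain that carries it, a question on which the methyl ester of that chain would bear.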